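The source may report more compounds than this note shows. Statements on the series, on what has been measured and on what is new or still open speak of the compounds shown alone.

Measured compounds in a functional assay on A549 cells (Homo sapiens) for antiproliferative activity, read by MTT assay, with a stated time of 48 h; on this read-out higher numbers stand for weaker inhibition and lower numbers for stronger inhibition:
compound 1, `COc1ccc(C(=O)c2ccc(OC)c3c2OC(C)(C)C=C3)c(NC(=O)CO)c1`, 80 nM
compound 2, `COc1ccc(C(=O)c2ccc(OC)c3c2OC(C)(C)C=C3)c(NC(=O)CN)c1`, 270 nM
compound 3, `C=C(c1ccc(OC)cc1NC(=O)CO)c1ccc(OC)c2c1C=CC(C)(C)O2`, 70 nM

Compound 1 and compound 2 share a core and differ by amino in place of hydroxy on a saturated chain carbon bound to a carbonyl carbon; this change gives a 3.4-fold higher number from compound 1 to compound 2 (0.53 log units; beyond the scatter). Compound 3 carries a different core; the difference between the two cores is not broken down here. Compound 3 and compound 1 give numbers within the scatter of each other, while compound 3 and compound 2 differ beyond it.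

Compound 4, `C=C(c1ccc(OC)cc1NC(=O)CN)c1ccc(OC)c2c1C=CC(C)(C)O2`, is not yet measured. It differs from compound 3 by amino in place of hydroxy on a saturated chain carbon bound to a carbonyl carbon, the same change as from compound 1 to compound 2, at a place described in the same words. The expectation for compound 4 rests on that single earlier step, because a 3.4-fold higher number from compound 1 to compound 2 (0.53 log units; beyond the scatter) was the outcome of the same change on the core of compound 1. A step of about a 3.4-fold higher number from compound 3 to compound 4 (0.54 log units; beyond the scatter) is expected again. Compound 4 is therefore estimated at 240 nM in this assay, between 120 nM and 480 nM. With one precedent only, the width allows for a smaller or larger effect on the second core.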

Compound 4, half-maximal inhibitory concentration: 90 nM
For compound 4 the middle estimate is 2.7-fold (0.43 log units) above the measured one; the whole stated range lies above it.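

In this assay, for the compounds shown here, amino in place of hydroxy on a saturated chain carbon bound to a carbonyl carbon gives a 1.3-fold higher number from compound 3 to compound 4 (0.11 log units; within the scatter), so on this second core the change produces no step that can be read apart from the scatter. Set beside the earlier step, the two outcomes cannot be told apart: the same change on two cores in this assay, a 3.4-fold higher number (0.53 log units; beyond the scatter) from compound 1 to compound 2 and a 1.3-fold higher number (0.11 log units; within the scatter) from compound 3 to compound 4, 2.6-fold (0.42 log units) apart, within the scatter of two such steps. The change therefore cannot be said to behave differently on the two cores, but this does not show that it behaves the same, and a step measured on one core gives only a loose guide to its size on the other.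

The compounds shown leave open how other groups on this saturated chain carbon, such as a dimethylamino group, a carboxylic acid or a longer chain bearing the amino group, would compare on the two cores. They also leave open whether the same change would carry to a third core.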